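Volume of distribution: swapping isobutyl for cyclohexyl

The source may hold more compounds than are shown below. What is called first, only, known or untested is meant among the compounds shown, and "the series" means these compounds.

Two compounds have a number in an in vivo ADME assay on the whole organism for pharmacokinetics, with Mus musculus as the target; on this read-out lower numbers stand for narrower distribution and higher numbers for wider distribution into tissues. Compound 1 `COc1cccc(-c2c(C)n(Cc3c(F)cccc3F)c(=O)n(C[C@H](C)NCc3ccccc3)c2=O)c1F` gives 7.9 L/kg, and compound 2 `COc1cccc(-c2c(C)n(Cc3c(F)cccc3F)c(=O)n(C[C@H](N)CC(C)C)c2=O)c1F` gives 3.9 L/kg, the lowest of the two. Within the data shown here, the one measured step, a 2.0-fold lower number from compound 1 to compound 2 (0.31 log units; beyond the scatter), changes a different part of the molecule. Compound 3 `COc1cccc(-c2c(C)n(Cc3c(F)cccc3F)c(=O)n(C[C@H](N)C3CCCCC3)c2=O)c1F` differs from compound 2 by cyclohexyl in place of isobutyl on a saturated chain carbon bound to an amine nitrogen and a saturated chain carbon. Among the measured compounds shown here, no measured step touches this place, so only a small change is expected, with a step of a 1.2-fold higher number from compound 2 to compound 3 (0.06 log units; within the scatter) in this assay that stays within the usual scatter. Compound 3 is therefore estimated at 4.5 L/kg, between 2.3 L/kg and 8.5 L/kg.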

Compound 3, volume of distribution: 7.3 L/kg
The estimate for compound 3 lay 1.6-fold (0.21 log units) below the measured number; low and high end bracket the measured number.
By their numbers in this assay, from the lowest: compounds 2, 3 and 1 (each within the scatter of the next, the first and the last beyond it).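

In this assay, among these compounds, cyclohexyl in place of isobutyl on this saturated chain carbon gives a 1.9-fold higher number from compound 2 to compound 3 (0.27 log units; within the scatter), the first measured change at this place, and it stays within the usual scatter. Amino(cyclohexyl)methyl in place of 1-(benzylamino)ethyl gives a 1.1-fold lower number from compound 1 to compound 3 (0.03 log units; within the scatter), so compound 3 cannot be told apart from either neighbour, although those two differ beyond the scatter. No evidence at hand bears on this result. From the compounds shown here alone, whether a phenyl or cyclopropyl group, or a chain carrying a hydroxyl, on this carbon would move the number beyond the scatter stays open.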